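Chloro on the pendant ring: cytotoxicity expectation for compound 4

The source may hold more compounds than are shown below. What is called first, only, known or untested is meant among the compounds shown, and "the series" means these compounds.

Compound 1 `O[C@@H]1Cc2ccccc2N[C@H](c2ccccc2)C1` gives > 300000 nM in an ADME assay on THP-1 cells (Homo sapiens) for cytotoxicity, read by MTT assay, with a stated time of 72 h (a lower number here means that less compound is tolerated, a higher number that more compound is tolerated), a limit of the assay.
Compound 2 `O[C@@H]1Cc2ccccc2N[C@H](c2ccccc2F)C1` gives > 300000 nM in this assay, likewise a limit.
Compound 3 `O[C@@H]1Cc2cc(Cl)ccc2N[C@H](c2ccccc2F)C1` gives 110000 nM in this assay.

Compound 2 stands at the ceiling of the measurement: its value is a limit, not a number, and it shares that position with compound 1, since both sit at the limit of > 300000 nM in this assay, at which 2 of the 3 values shown sit. The step that the two limits leave unreadable from compound 1 to compound 2 therefore cannot be read because of the limit of > 300000 nM in this assay, at which 2 of the 3 values shown sit. Among the compounds with values here, the one readable step is an at least 2.7-fold lower number from compound 2 to compound 3 (0.43 log units; beyond the scatter), where a chloro entered on an aromatic carbon of the fused ring.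

Compound 4 `O[C@@H]1Cc2ccccc2N[C@H](c2c(F)cccc2Cl)C1` differs from compound 2 by chloro in place of hydrogen on an aromatic carbon. This is again a chloro in place of hydrogen on an aromatic carbon, but on the pendant ring rather than on the ring where compound 3 carried it, so the step from compound 2 to compound 3 bears on it only loosely. A modest lowering is expected, smaller than the measured one, and the result may again come back as a limit. Compound 4 is therefore estimated at 200000 nM, between 80000 nM and 400000 nM, which corresponds to an expected step of an at least 1.5-fold lower number from compound 2 to compound 4 (0.17 log units; that floor lies within the scatter).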

Compound 4, half-maximal cytotoxic concentration: > 300000 nM
Compound 4 ended at the assay's limit; the forecaster's own chance of this, stated with the estimate: 45%; middle value at least 1.5-fold (0.17 log units) from the limit.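

Compound 4 gives > 300000 nM in this assay, which is a limit of the assay, and no step from compound 2 to compound 4 can be read because both compounds sit at that limit: the limit of > 300000 nM in this assay, at which 3 of the 4 values shown sit.

The compounds shown leave open whether a chloro on the pendant ring changes this number at all.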